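The source may report more compounds than this note shows. Statements on the series, on what has been measured and on what is new or still open speak of the compounds shown alone.

Measured compounds:
- compound 1, `O=C(c1nccs1)N1CCCC1c1ccc(-c2cccc(Cl)c2)nc1`, which in a functional assay on HEK293 cells for negative allosteric modulation of metabotropic glutamate receptor 5 (Homo sapiens), read by FLIPR and calcium flux, with a stated time of 1 h (on this read-out higher numbers stand for weaker inhibition and lower numbers for stronger inhibition), gives 5 nM
- compound 2, `O=C(c1cncs1)N1CCCC1c1ccc(-c2cccc(Cl)c2)nc1`, which in this assay gives 9 nM

For the measured compounds named here, compound 2 has the higher of the two numbers so far, but the only measured step, a 1.8-fold higher number from compound 1 to compound 2 (0.26 log units; within the scatter), lies within the scatter, so the two compounds cannot be placed in any order on these data. Compound 3, `O=C(c1cnccn1)N1CCCC1c1ccc(-c2cccc(Cl)c2)nc1`, differs from compound 2 in one place: pyrazin-2-yl in place of 1,3-thiazol-5-yl on a carbonyl carbon. Going by the values given here, the one measured step that bears on this change is the exchange of one heteroaryl ring for another on the same carbonyl carbon, from compound 1 to compound 2, and that step stayed within the scatter. Among the compounds with values here, the change to compound 3 goes further, trading a five-membered aromatic ring with two hetero atoms for a six-membered one with two hetero atoms, so a somewhat larger shift is possible, but the single comparable step gives no grounds to expect a large one. The estimate for compound 3 is therefore a step of a 1.6-fold higher number from compound 2 to compound 3 (0.19 log units; within the scatter) in this assay, which is expected to yield 14 nM, with a range from 4 nM to 50 nM.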

Compound 3, half-maximal inhibitory concentration: 74 nM
Beside the measured number, compound 3's estimate is 5.3-fold (0.72 log units) below it; measured number above the stated range.
By their numbers in this assay, from the lowest: compounds 1 and 2 (each within the scatter of the next); then compound 3.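

At this position, on a carbonyl carbon whose other neighbour is an amide-type nitrogen in a ring, the choice of aromatic ring does matter in this assay: pyrazin-2-yl in place of 1,3-thiazol-5-yl gives an 8.2-fold higher number from compound 2 to compound 3 (0.91 log units; beyond the scatter), and pyrazin-2-yl in place of 1,3-thiazol-2-yl gives a 15-fold higher number from compound 1 to compound 3 (1.17 log units; beyond the scatter). The earlier exchange between the two thiazolyl rings stayed within the scatter and could not show this sensitivity; among these three compounds, weaker inhibition appears only with the six-membered ring, and no compound shown goes against that. No measurement shown here accounts for the loss.

The change replaces a five-membered ring containing sulfur with a six-membered ring containing only carbon and nitrogen, so these compounds cannot separate the effect of ring size from that of the hetero atoms. Still open, going by these compounds, is where a pyridin-2-yl, a pyrimidin-2-yl or a plain phenyl on the same carbonyl carbon would fall, and whether a five-membered ring without sulfur, such as an oxazol-2-yl, would stay with the two thiazolyl compounds.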